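From methoxy to dichloro on a shared core

The source may report more compounds than this note shows. Statements on the series, on what has been measured and on what is new or still open speak of the compounds shown alone.

Measured in a functional assay on A549 cells (Homo sapiens) for cytotoxicity, read by MTT assay, with a stated time of 72 h; on this read-out lower numbers stand for stronger inhibition and higher numbers for weaker inhibition:
Compound 1 `COc1ccccc1/C=C1\CCC/C(=C\c2ccc(OC)c(OC)c2)C1=O`: > 20000 nM, a limit
Compound 2 `COc1cccc(/C=C2\CCC/C(=C\c3ccc(OC)c(OC)c3)C2=O)c1`: 6700 nM

Among the measured compounds shown here, compound 2 holds the only actual number here; the entry for compound 1 is a limit and not a number. Compound 3 `COc1ccc(/C=C2\CCC/C(=C\c3ccc(Cl)c(Cl)c3)C2=O)cc1OC` has not been measured yet. It differs from compound 2 in one place: 3,4-dichlorophenyl in place of 3-methoxyphenyl on a double-bonded chain carbon bound to a double-bonded ring carbon. For the measured compounds named here, only one measured step bears on this place: an at least 2.9-fold lower number from compound 1 to compound 2 (0.47 log units; beyond the scatter). That step swapped 2-methoxyphenyl for 3-methoxyphenyl, so it shows that the number can move with a change here, but it gives no direction for 3,4-dichlorophenyl. In this assay no step beyond the scatter is therefore expected, although the uncertainty is wide in both directions. The expected step is a 1.3-fold lower number from compound 2 to compound 3 (0.13 log units; within the scatter). For compound 3 the estimated value is 5000 nM, with an expected range from 1500 nM to 18000 nM.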

Compound 3, half-maximal inhibitory concentration: 6900 nM
Compound 3: middle estimate off by 1.4-fold (0.14 log units), on the low side; measured number inside the range.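

In this assay, putting 3,4-dichlorophenyl in place of 3-methoxyphenyl on a double-bonded chain carbon bound to a double-bonded ring carbon gives a 1.0-fold higher number from compound 2 to compound 3 (0.01 log units; within the scatter), so a group with 0 hydrogen-bond acceptors reads the same here as one with 1. Set against the 2-methoxyphenyl group, the same 3,4-dichlorophenyl group gives an at least 2.8-fold lower number from compound 1 to compound 3 (0.46 log units; beyond the scatter), so two different groups at this place now stand apart from the 2-methoxyphenyl group. The size of that step is only a bound, because the entry for compound 1 is a limit and not a number: the limit of > 20000 nM in this assay, at which 1 of the 3 values shown sits.

The compounds shown leave open whether a group of another kind on this phenyl ring, such as an amine or a carboxylic acid, would move the number beyond the scatter. They also leave open whether a single chlorine would read the same as two.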